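Benzyl to 4-methoxybenzyl on compound 1

The compounds below may be only part of what the source reports. "The series", "measured", "known", "first", "only" and "open" are said of these compounds alone.

For the measured compounds named here, in a functional assay on A-431 cells (Homo sapiens) for inhibition, read by sulforhodamine B assay, with a stated time of 72 h (on this read-out lower numbers stand for stronger inhibition and higher numbers for weaker inhibition), compound 1 (`COc1ccc(CN(Cc2ccccc2)Cc2c(O)ccc3c(=O)cc(C)oc23)cc1`) gives 44.7 ug/mL as the only true number so far. Compound 2 (`COc1ccc(CN(Cc2ccc([N+](=O)[O-])cc2)Cc2c(O)ccc3c(=O)cc(C)oc23)cc1`) sits at > 100 ug/mL in this assay and this is a limit of the assay, not a number.

Compound 3 (`COc1ccc(CN(Cc2ccc(OC)cc2)Cc2c(O)ccc3c(=O)cc(C)oc23)cc1`) differs from compound 1 by methoxy in place of hydrogen on an aromatic carbon and the change reads benzyl to 4-methoxybenzyl, with methoxy in place of hydrogen on an aromatic carbon.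

Going by the values given here, one measured step bears on this. Nitro in place of hydrogen on an aromatic carbon gives an at least 2.2-fold higher number from compound 1 to compound 2 (0.34 log units; beyond the scatter) and so points to weaker inhibition, beyond the scatter. The size of that step rests on the limit of > 100 ug/mL in this assay, at which 1 of the 2 values shown sits, alone. Nitro and methoxy are different groups, so this single step carries over only loosely.

The expectation is therefore a small move towards a higher number, probably not beyond the scatter. The expected step is a 1.3-fold higher number from compound 1 to compound 3 (0.13 log units; within the scatter) in this assay as a working figure. For compound 3 the estimated value is 60 ug/mL with an estimated range from 25 ug/mL to 100 ug/mL as the working bracket.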

Compound 3, half-maximal inhibitory concentration: 38.9 ug/mL
Compound 3: middle estimate off by 1.5-fold (0.19 log units), on the high side, and the stated range covers the measured number.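

In this assay, methoxy in place of hydrogen on this aromatic carbon, para to a large group, gives a 1.1-fold lower number from compound 1 to compound 3 (0.06 log units; within the scatter), so this carbon carries a methoxy with no readable change from hydrogen, which the nitro step alone could not show. Methoxy in place of nitro at the same carbon gives an at least 2.5-fold lower number from compound 2 to compound 3 (0.41 log units; beyond the scatter), so the outcome here depends on which group enters and not merely on whether the hydrogen is replaced. The size of that step is open on one side, as the reading for compound 2 is a limit of the assay and not a number: the limit of > 100 ug/mL in this assay, at which 1 of the 3 values shown sits.

Only hydrogen, methoxy and nitro are shown at this carbon, so it remains open whether an amine, a carboxylic acid or a chlorine atom there would stay with the first two or fall with nitro. From the compounds shown here alone, it also remains open how a longer chain in place of the benzyl group would read on the shared core.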